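A few compounds are considered here, and "the series" means these few. Any claim that something is new, unique, unknown or untested is made for them only; others in the source may bear on it.

Working notes on a set of long-chain amides that share a sulfonamide and a secondary alcohol on one core.

Compound 1 `CCCCCCCCCCCCNC(=O)[C@@H](NS(=O)(=O)c1ccc(C)cc1)[C@@H](C)O` in a functional assay on SW-620 cells (Homo sapiens) for cytotoxicity, read by MTT assay, with a stated time of 48 h (a lower number here means a stronger inhibitor, a higher number a weaker inhibitor), gives 25600 nM. Compound 2 `CCCCCCCCCCCCNC(=O)[C@@H](NS(=O)(=O)c1cccs1)[C@@H](C)O` carries thiophen-2-yl in place of 4-methylphenyl on a sulfonyl sulfur; in this assay compound 2 gives 27900 nM, and the step is a 1.1-fold higher number from compound 1 to compound 2 (0.04 log units; within the scatter). Compound 3 `CCCCCCCCCCCCCCNC(=O)[C@@H](NS(=O)(=O)c1ccc(C)cc1)[C@@H](C)O` differs from compound 1 by ethyl in place of hydrogen on a saturated chain carbon, ten or more bonds along the chain from an amide-type nitrogen; in this assay compound 3 gives 15200 nM, the step being a 1.7-fold lower number from compound 1 to compound 3 (0.23 log units; within the scatter). All three values lie within the scatter of one another, so no ordering among them is drawn.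

Compound 4 `CCCCCCCCCCCCCCNC(=O)[C@@H](NS(=O)(=O)c1cccs1)[C@@H](C)O` is not yet measured. It stands to compound 3 as compound 2 stands to compound 1: the change is thiophen-2-yl in place of 4-methylphenyl on a sulfonyl sulfur, the same change as that from compound 1 to compound 2, now made on the core of compound 3, which carries the ethyl in place of hydrogen described above. The expected step in this assay is a 1.1-fold higher number from compound 3 to compound 4 (0.04 log units; within the scatter), a step of about the earlier size, because a 1.1-fold higher number from compound 1 to compound 2 (0.04 log units; within the scatter) was within the scatter. Compound 4 is therefore estimated to give about 16500 nM in this assay, with an expected range from 8000 nM to 34000 nM.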

Compound 4, half-maximal inhibitory concentration: 18400 nM
The estimate for compound 4 lay 1.1-fold (0.05 log units) below the measured number, within the range that was stated.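

In this assay, thiophen-2-yl in place of 4-methylphenyl on a sulfonyl sulfur gives a 1.2-fold higher number from compound 3 to compound 4 (0.08 log units; within the scatter), and this change reads the same on both cores: the same change on two cores in this assay, a 1.1-fold higher number (0.04 log units; within the scatter) from compound 1 to compound 2 and a 1.2-fold higher number (0.08 log units; within the scatter) from compound 3 to compound 4, 1.1-fold (0.05 log units) apart, within the scatter of two such steps The ethyl in place of hydrogen on a saturated chain carbon, ten or more bonds along the chain from an amide-type nitrogen, gives a 1.5-fold lower number from compound 2 to compound 4 (0.18 log units; within the scatter), and it also reads the same whichever group sits on the sulfonyl sulfur: the same change on two cores in this assay, a 1.7-fold lower number (0.23 log units; within the scatter) from compound 1 to compound 3 and a 1.5-fold lower number (0.18 log units; within the scatter) from compound 2 to compound 4, 1.1-fold (0.05 log units) apart, within the scatter of two such steps The two changes therefore show no sign of depending on each other across these four compounds, but each step lies within the scatter, so this agreement is between steps too small to separate from no change and does not show that either change has a real effect that transfers.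

Going by these compounds, whether a much longer chain, or an amine or a carboxylic acid in place of the thiophen-2-yl, would give a step beyond the scatter stays open. The compounds shown also leave open what a methyl ether in place of the secondary alcohol would do.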